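The compounds below may be only part of what the source reports. "The series", "measured", "known", "first", "only" and "open" are said of these compounds alone.

Three compounds have been measured in a functional assay on PC-3 cells (Homo sapiens) for antiproliferative activity, read by MTT assay, with a stated time of 48 h; a lower number here means a stronger inhibitor, a higher number a weaker inhibitor:

compound 1, `COc1ccc(CN(C(=O)CSc2nc3ccc(OC)cc3s2)c2cc(OC)c(OC)c(OC)c2)cc1`, giving 20200 nM
compound 2, `COc1ccc(CN(C(=O)CSc2nnnn2C)c2cc(OC)c(OC)c(OC)c2)cc1`, giving 10500 nM
compound 3, `COc1ccc(CN(C(=O)CSc2ccccn2)c2cc(OC)c(OC)c(OC)c2)cc1`, giving 7510 nM

Compound 3 has the lowest of the three numbers. Its nearest neighbour is compound 2, and the step of a 1.4-fold lower number from compound 2 to compound 3 (0.15 log units; within the scatter) lies within the scatter, so the two cannot be ranked against each other. Its furthest neighbour is compound 1, and the step of a 2.7-fold lower number from compound 1 to compound 3 (0.43 log units; beyond the scatter) is beyond the scatter, though only modest.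

Compound 4, `COc1ccc(CN(C(=O)CSc2nc3ccccc3[nH]2)c2cc(OC)c(OC)c(OC)c2)cc1`, differs from compound 3 in one place: 1H-benzimidazol-2-yl in place of pyridin-2-yl on a sulfur. The change returns to a fused bicyclic group on the sulfur, which is what compound 1 carries, while compound 2 and compound 3 carry single rings. Going by the values given here, the only measured steps that bear on this are a 2.7-fold lower number from compound 1 to compound 3 (0.43 log units; beyond the scatter), which runs from a bicyclic group to a single ring, and a 1.9-fold lower number from compound 1 to compound 2 (0.28 log units; within the scatter), within the scatter. Neither involves the 1H-benzimidazol-2-yl group itself, so the guidance is loose. On that basis, compound 4 is expected to sit near compound 3 or somewhat higher, with an expected step of a 1.3-fold higher number from compound 3 to compound 4 (0.12 log units; within the scatter). The estimate for compound 4 is 10000 nM, with a range from 4000 nM to 25000 nM.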

Compound 4, half-maximal inhibitory concentration: 14400 nM
Compound 4: the middle estimate sits 1.4-fold (0.16 log units) below what was measured; the measured number falls inside the stated range.
By their numbers in this assay, from the lowest: compounds 3, 2, 4 and 1 (each within the scatter of the next, the first and the last beyond it).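

In this assay, 1H-benzimidazol-2-yl brings to this place on the sulfur a hydrogen-bond donor that pyridin-2-yl lacks, but that change gives no readable difference: a 1.9-fold higher number from compound 3 to compound 4 (0.28 log units; within the scatter). Going by these compounds alone, the other two steps, a 1.4-fold higher number from compound 2 to compound 4 (0.14 log units; within the scatter) and a 1.4-fold lower number from compound 1 to compound 4 (0.15 log units; within the scatter), also stay within the scatter, so compound 4 cannot be ranked against any of the other three compounds, and the two-ring groups of compound 1 and compound 4 do not separate as a set from the single rings of compound 2 and compound 3, although a 2.7-fold lower number from compound 1 to compound 3 (0.43 log units; beyond the scatter) remains beyond the scatter. Nothing available explains these numbers or shows why the groups compare as they do.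

As far as these compounds go, all four groups are aromatic rings held on the sulfur, so it remains open whether an amine, a carboxylic acid or a longer alkyl chain at this place would give a clearly different number. From the compounds shown here alone, it is also open whether the methoxy group on the 6-methoxy-1,3-benzothiazol-2-yl of compound 1 contributes to its value, which an unsubstituted 1,3-benzothiazol-2-yl group would help to settle.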